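The source may report more compounds than this note shows. Statements on the series, on what has been measured and on what is new or still open speak of the compounds shown alone.

Measured compounds:
compound 1, `Cn1c(-c2ccc(NC(=O)CSc3nc4ccccc4o3)cc2)nc(-c2ccccc2)c1-c1ccccc1`, 11.2 ug/mL in a functional assay on MCF7 cells (Homo sapiens) for cytotoxicity, read by MTT assay, with a stated time of 24 h; a lower number here means a stronger inhibitor, a higher number a weaker inhibitor.
compound 2, `Cn1nnnc1SCC(=O)Nc1ccc(-c2nc(-c3ccccc3)c(-c3ccccc3)n2C)cc1`, 4.5 ug/mL in this assay.

Compound 2 has the lowest of the two numbers in this assay; compound 1 sits a 2.5-fold lower number from compound 1 to compound 2 (0.40 log units; beyond the scatter) away. Compound 3, `Cc1nnc(SCC(=O)Nc2ccc(-c3nc(-c4ccccc4)c(-c4ccccc4)n3C)cc2)s1`, differs from compound 2 in one place: 5-methyl-1,3,4-thiadiazol-2-yl in place of 1-methyl-1H-tetrazol-5-yl on a sulfur. Among the compounds with values here, the only measured step that bears on this swap is the one from compound 1 to compound 2, a modest 2.5-fold lower number from compound 1 to compound 2 (0.40 log units; beyond the scatter), which shows that the group on this sulfur can move the number by a modest amount. Compound 3 is therefore expected to land near compound 2, with a 1.3-fold higher number from compound 2 to compound 3 (0.12 log units; within the scatter), so its estimate in this assay is 6 ug/mL, within 2.5 ug/mL to 15 ug/mL.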

Compound 3, half-maximal inhibitory concentration: 3.2 ug/mL
Compound 3: middle estimate off by 1.9-fold (0.27 log units), on the high side; the measured number falls inside the stated range.
By their numbers in this assay, from the lowest: compounds 3 and 2 (each within the scatter of the next); then compound 1.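

In this assay, placing 5-methyl-1,3,4-thiadiazol-2-yl on the sulfur in place of 1-methyl-1H-tetrazol-5-yl gives a 1.4-fold lower number from compound 2 to compound 3 (0.15 log units; within the scatter), so these two five-membered aromatic rings cannot be told apart here. The 1,3-benzoxazol-2-yl group of compound 1 stands apart from both, and the second comparison is a 3.5-fold lower number from compound 1 to compound 3 (0.54 log units; beyond the scatter), which matches the earlier step from that compound. No measurement is available to explain these numbers.
The compounds shown leave open whether a group without a ring on this sulfur, such as a carboxylic acid or a simple amine, would keep the number in this range.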